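The source may hold more compounds than are shown below. What is called first, only, known or untested is meant among the compounds shown, and "the series" means these compounds.

Measured so far in a functional assay on RT-112 cells (Homo sapiens) for antiproliferative activity, read by MTT assay, with a stated time of 48 h; on this read-out higher numbers stand for weaker inhibition and lower numbers for stronger inhibition:

Compound 1 `CN1CCN(c2ccccc2/C=C/C(=O)c2cn(C)c3ccccc23)CC1` gives 26400 nM.
Compound 2 `COc1cc(OC)c(/C=C/C(=O)c2cn(C)c3ccccc23)c(OC)c1` gives 3200 nM.

Compound 2 stands at the lowest of the two numbers in this assay, and the nearest value, that of compound 1, lies a gap above it that is beyond the usual scatter. Compound 3 `COc1cc(OC)c(/C=C/C(=O)c2cn(C)c3ccc(OC)cc23)c(OC)c1` keeps the whole of compound 2 and differs from it in one place: methoxy in place of hydrogen on an aromatic carbon. Among the compounds with values here, no pair of measured compounds shows what this particular change does on the shared core, so the expected size of the step rests only on the fact that compound 2 is left otherwise untouched. On that basis the step in this assay is expected to be small, in either direction, and most likely not beyond the scatter. Compound 3 is therefore expected to show 2500 nM, within a range from 800 nM to 8000 nM. The step from compound 2 that this estimate means is a 1.3-fold lower number from compound 2 to compound 3 (0.11 log units; within the scatter), which is expected to sit close to the value of compound 2.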

Compound 3, half-maximal inhibitory concentration: 3100 nM
Estimate against measurement, compound 3: 1.2-fold (0.09 log units) below, within the range that was stated.
By their numbers in this assay, from the lowest: compounds 3 and 2 (each within the scatter of the next); then compound 1.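

In this assay, methoxy in place of hydrogen on this aromatic carbon, in the six-membered aromatic ring of carbon only that is part of the fused system, gives a 1.0-fold lower number from compound 2 to compound 3 (0.01 log units; within the scatter), so the two compounds cannot be told apart on this read-out. Within the data shown here, this is the first reading of any change at this position, and it shows that this position of the shared core can carry a methoxy, with its 2 heavy atoms and 1 hydrogen-bond acceptor, without a step beyond the scatter, a statement that holds for this one group on this one core. Nothing in the data speaks to why the number stays where it is.

The compounds shown leave open whether a different group at this position, such as an amine, a carboxylic acid or a longer chain like butoxy, would also leave the number within the scatter of compound 2. They also leave open whether the same methoxy would give a similar step at another carbon of this ring, or on the core of compound 1.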